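Aromatic nitrogen substituent: cyclohexyl to benzyl

The source may report more compounds than this note shows. Statements on the series, on what has been measured and on what is new or still open speak of the compounds shown alone.

Compound 3 `CN1C(=S)[C@@H](NC(=O)c2nc(Cc3ccccc3)n(C3CCCCC3)n2)COc2ccccc21` carries a cyclohexyl on an aromatic nitrogen of the shared core. In a toxicity assay on HT-29 cells (Homo sapiens) for cytotoxicity (a lower number here means that less compound is tolerated, a higher number that more compound is tolerated), compound 3 gives only a limit, > 100000 nM. Compound 1 `CCCCn1nc(C(=O)N[C@H]2COc3ccccc3N(C)C2=S)nc1Cc1ccccc1` carries butyl on that aromatic nitrogen. In this assay compound 1 likewise gives a limit, > 100000 nM. Compound 2 `CN1C(=S)[C@@H](NC(=O)c2nc(Cc3ccccc3)n(CCCO)n2)COc2ccccc21` carries 3-hydroxypropyl on that aromatic nitrogen. In this assay compound 2 also returns a limit, > 100000 nM. The steps a step that the two limits leave unreadable from compound 1 to compound 3 and a step that the two limits leave unreadable from compound 2 to compound 3 are therefore unreadable, as is a step that the two limits leave unreadable from compound 1 to compound 2; all three values sit at the limit of > 100000 nM in this assay, at which 3 of the 3 values shown sit.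

Compound 4 `CN1C(=S)[C@@H](NC(=O)c2nc(Cc3ccccc3)n(Cc3ccccc3)n2)COc2ccccc21` differs from compound 3 by benzyl in place of cyclohexyl on an aromatic nitrogen. The two measured steps on this aromatic nitrogen, cyclohexyl in place of butyl and cyclohexyl in place of 3-hydroxypropyl, bear on this change, but neither gives a readable size, and none gives a direction. No step beyond the scatter is expected in this assay for a step that the limit leaves unreadable from compound 3 to compound 4. Compound 4 is expected to give 150000 nM, in the range 50000 nM to 500000 nM, most likely again reported as a limit.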

Compound 4, half-maximal cytotoxic concentration: > 100000 nM
Compound 4: no number, only a limit (the forecaster's own chance of this, stated with the estimate: 80%); the middle value lies beyond the limit too.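

Compound 4 also returns only a limit, so no step among compound 1, compound 2, compound 3 and compound 4 can be read: the limit of > 100000 nM in this assay, at which 4 of the 4 values shown sit.

Going by these compounds, whether any group on this aromatic nitrogen shifts the value in this assay stays open, in both size and direction.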